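Dichloroacetanilides: phenyl in place of pyridin-2-yl

A few compounds are considered here, and "the series" means these few. Any claim that something is new, unique, unknown or untested is made for them only; others in the source may bear on it.

Measured so far:
compound 1 `O=C(Nc1cccc(-c2ccccn2)c1)C(Cl)Cl` — > 50000 nM
compound 2 `CSc1ccc(-c2cc(NC(=O)C(Cl)Cl)cc(-c3ccc(SC)cc3)c2)cc1` — > 30000 nM
compound 3 `CCOc1cccc(-c2cc(NC(=O)C(Cl)Cl)cc(-c3cccc(OCC)c3)c2)c1` — 4950 nM

In a functional assay on NCI-H460 cells (Homo sapiens) for cytotoxicity, read by MTT assay, with a stated time of 68 h (on this read-out lower numbers stand for stronger inhibition and higher numbers for weaker inhibition), compound 1 returns no number, only a limit, > 50000 nM. Compound 2 likewise returns only a limit in this assay, > 30000 nM. Going by the values given here, compound 3 is the single member with a measured number in this assay, giving 4950 nM. Two of the three values shown are thus limits: the limit of > 50000 nM in this assay, at which 1 of the 3 values shown sits, where compound 1 sits, and (the limit of > 30000 nM in this assay, at which 1 of the 3 values shown sits), where compound 2 sits. Compound 1 therefore stands at the weak end of what has been seen in this set, with no measured number to place it more precisely. Among the compounds with values here, no pair of measured compounds differs in one place, so no measured step is available for comparison.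

Compound 4 `O=C(Nc1cccc(-c2ccccc2)c1)C(Cl)Cl` is the next compound, differing from compound 1 by phenyl in place of pyridin-2-yl on an aromatic carbon. The change keeps the dichloroacetamide and the core of compound 1 intact and swaps only the attached aromatic ring. Given that compound 1 shows only a limit, > 50000 nM, the step from compound 1 to compound 4 in this assay is expected to stay within the scatter, a step that the limit leaves unreadable from compound 1 to compound 4, with no clear direction. Compound 4 is accordingly estimated at 60000 nM, within 15000 nM to 200000 nM, and most likely reported again as a limit.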

Compound 4, half-maximal inhibitory concentration: 20200 nM
Compound 4: middle estimate off by 3.0-fold (0.47 log units), on the high side; low and high end bracket the measured number.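

Notes on the ring at this position, with the dichloroacetamide and the rest of the shared core unchanged: in this assay, phenyl in place of pyridin-2-yl, on an aromatic carbon meta to a ((dichloromethyl)carbonyl)amino group, gives an at least 2.4-fold lower number from compound 1 to compound 4 (0.39 log units; beyond the scatter). Going by these compounds alone, this is the first comparison in the set that differs in one place, and it shows that the identity of this ring is not neutral: replacing a single ring nitrogen with carbon is enough to turn a limit into a measured number. Compound 1 remains a limit, so the true size of the step is not known and only its direction and minimum can be read: the limit of > 50000 nM in this assay, at which 1 of the 4 values shown sits.

This single pair gives no cause for the change, and it cannot separate an effect of removing the ring nitrogen from any other account. Still open, as far as these compounds go, are whether pyridin-3-yl would read like pyridin-2-yl or like phenyl, whether an amine or a carboxylic acid on the phenyl ring of compound 4 would move the number further, and whether the same swap holds on cores that carry a second aromatic ring.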